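Swapping Methyl for Fluoro on a Shared Core

The source may hold more compounds than are shown below. What is called first, only, known or untested is meant among the compounds shown, and "the series" means these compounds.

Compound 2 `Cc1cnc(Nc2ccc(S(N)(=O)=O)cc2)nc1Nc1nc2ccc(Cl)cc2s1` and compound 1 `NS(=O)(=O)c1ccc(Nc2ncc(F)c(Nc3nc4ccc(Cl)cc4s3)n2)cc1` differ by fluoro in place of methyl on an aromatic carbon. In a functional assay on MCF7 cells (Homo sapiens) for antiproliferative activity, read by MTT assay, with a stated time of 48 h (a lower number here means a stronger inhibitor, a higher number a weaker inhibitor), compound 2 gives 8430 nM and compound 1 gives 8340 nM, a step of a 1.0-fold lower number from compound 2 to compound 1 (0.00 log units; within the scatter). Compound 3 `COc1ccc2nc(Nc3nc(Nc4ccc(S(N)(=O)=O)cc4)ncc3C)sc2c1` differs from compound 2 by methoxy in place of chloro on an aromatic carbon. In this assay compound 3 gives > 50000 nM, which is a limit of the assay and not a number. The step of an at least 5.9-fold higher number from compound 2 to compound 3 (0.77 log units; beyond the scatter) can only be stated as a bound because compound 3 sits at the limit of > 50000 nM in this assay, at which 1 of the 3 values shown sits. Compound 4 `COc1ccc2nc(Nc3nc(Nc4ccc(S(N)(=O)=O)cc4)ncc3F)sc2c1` has not been measured; it differs from compound 3 by fluoro in place of methyl on an aromatic carbon, the same change as from compound 2 to compound 1. Because that earlier change gave a 1.0-fold lower number from compound 2 to compound 1 (0.00 log units; within the scatter), the step to compound 4 is expected to be a step that the limit leaves unreadable from compound 3 to compound 4. Compound 4 is therefore estimated at 60000 nM, most likely once more reported only as a limit.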

Compound 4, half-maximal inhibitory concentration: > 50000 nM
Compound 4 ended at the assay's limit; the forecaster's own chance of this, stated with the estimate: 75%; the middle value does not contradict the limit.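

In this assay compound 4 gives > 50000 nM, which is a limit of the assay and not a number. Fluoro in place of methyl gives a 1.0-fold lower number from compound 2 to compound 1 (0.00 log units; within the scatter) on the chloro core, but the same swap cannot be read on the methoxy core, so whether that result carries over remains unknown: the limit of > 50000 nM in this assay, at which 2 of the 4 values shown sit. Methoxy in place of chloro gives an at least 5.9-fold higher number from compound 1 to compound 4 (0.77 log units; beyond the scatter), and it points the same way on both cores: the same change on two cores in this assay, an at least 5.9-fold higher number (0.77 log units; beyond the scatter) from compound 2 to compound 3 and an at least 5.9-fold higher number (0.77 log units; beyond the scatter) from compound 1 to compound 4; the limit leaves it open whether they differ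

From the compounds shown here alone, it remains open whether a group other than chloro or methoxy on that carbon, such as an amine or a carboxylic acid, would give values short of the limit. Only such a pair could show whether the fluoro and methyl swap stays without a clear effect on another core.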